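Furan ester series: aryl swap at the furan carbon

A few compounds are considered here, and "the series" means these few. Any claim that something is new, unique, unknown or untested is made for them only; others in the source may bear on it.

Among the measured compounds shown here, two esters of the shared core have numbers so far. Compound 1 `COc1cc(COC(=O)c2ccc(-c3ccccc3C(F)(F)F)o2)cc(OC)c1OC` gives 54.9% in an assay on isolated protein for inhibition of high affinity 3',5'-cyclic-AMP phosphodiesterase 7A (Homo sapiens), read by scintillation proximity assay and cAMP accumulation, with a stated time of 20 min, tested at 10 uM; a lower number here means less inhibition, a higher number more inhibition at the concentration tested (going by the name of the read-out). For the measured compounds named here, compound 2 `COc1cc(COC(=O)c2ccc(-c3cccc(C(F)(F)F)c3)o2)cc(OC)c1OC` gives 14% in this assay, the lowest of the two; the only measured step, a number 40.9 percentage points lower from compound 1 to compound 2 (beyond the scatter), shows that this position is sensitive to where the trifluoromethyl sits on the phenyl ring. Compound 3 `COc1ccc(-c2ccc(C(=O)OCc3cc(OC)c(OC)c(OC)c3)o2)cc1` is not yet measured; it differs from compound 2 by 4-methoxyphenyl in place of 3-(trifluoromethyl)phenyl on an aromatic carbon. Going by the values given here, no measured step pairs a 4-methoxyphenyl against a 3-(trifluoromethyl)phenyl here, so the measured step gives only the scale of change this position can show, not its direction. Compound 2 sits at the low end, so a further large drop is bounded. For compound 3 the expected step is a number 8 percentage points higher from compound 2 to compound 3 (within the scatter), a mild rise that is within the scatter. Compound 3 is therefore estimated at 22% in this assay, with a range from 0% to 50%.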

Compound 3, a percentage reported as inhibition, at one concentration (the size of the read-out at that concentration, not a potency): 14%
Beside the measured number, compound 3's estimate is 8 percentage points above it; low and high end bracket the measured number.
By their numbers in this assay, from the lowest: compounds 2 and 3 (each within the scatter of the next); then compound 1.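

In this assay, 4-methoxyphenyl in place of 3-(trifluoromethyl)phenyl gives no change at the digits printed from compound 2 to compound 3 (within the scatter), so this position does not separate these two groups even though only one of them carries trifluoromethyl. Against 2-(trifluoromethyl)phenyl, the same 4-methoxyphenyl gives a number 40.9 percentage points lower from compound 1 to compound 3 (beyond the scatter), so the large gap to compound 1 now appears with two different aryl groups rather than one, and compound 1 stands apart from both. Nothing at hand explains the matching pair or the gap to compound 1.

Open, going by these compounds, is whether any group other than 2-(trifluoromethyl)phenyl can raise the number at this carbon, for instance a phenyl ring bearing an amine or a carboxylic acid. The compounds shown also leave open how the series reads with an amide in place of the ester.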